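Methyl to Ethyl Carried From One Core to Another

A few compounds are considered here, and "the series" means these few. Any claim that something is new, unique, unknown or untested is made for them only; others in the source may bear on it.

Compound 1 `CN1CCN(CC(=O)O[C@@H]2C[C@@H]3CC[C@@]2(C)C3(C)C)CC1` and compound 2 `CCN1CCN(CC(=O)O[C@@H]2C[C@@H]3CC[C@@]2(C)C3(C)C)CC1` share one core and differ by methyl in place of hydrogen on a saturated chain carbon bound to an amine nitrogen in a ring. In an ADME assay on HEK-293T cells (Homo sapiens) for cytotoxicity, read by MTT assay, with a stated time of 48 h (on this read-out lower numbers stand for higher toxicity in this test and higher numbers for lower toxicity in this test), compound 1 gives 313000 nM, while compound 2 gives 130000 nM, a step of a 2.4-fold lower number from compound 1 to compound 2 (0.38 log units; beyond the scatter). Compound 3 `CN1CCN(CCC(=O)N[C@@H]2C[C@H]3CC[C@]2(C)C3(C)C)CC1` is built on a second core; the difference between the two cores is not broken down here. In this assay compound 3 gives 486000 nM, which sits within the scatter of the number for compound 1 and beyond it relative to compound 2.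

Compound 4 `CCN1CCN(CCC(=O)N[C@@H]2C[C@H]3CC[C@]2(C)C3(C)C)CC1` carries the same change on the core of compound 3: methyl in place of hydrogen on a saturated chain carbon bound to an amine nitrogen in a ring. Among the compounds with values here, because the only measured instance of this change is a 2.4-fold lower number from compound 1 to compound 2 (0.38 log units; beyond the scatter), a step of similar size is expected here, a 2.4-fold lower number from compound 3 to compound 4 (0.39 log units; beyond the scatter). Compound 4 is therefore estimated at 200000 nM in this assay, spanning 100000 nM to 420000 nM, an expectation resting on a single precedent.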

Compound 4, half-maximal cytotoxic concentration: 565000 nM
Estimate against measurement, compound 4: 2.8-fold (0.45 log units) below; measured number above the stated range.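

On the second core, the methyl to ethyl change gives a 1.2-fold higher number from compound 3 to compound 4 (0.07 log units; within the scatter) in this assay and so does not repeat the step seen on the first core. Set side by side, the two steps differ: the same change on two cores in this assay, a 2.4-fold lower number (0.38 log units; beyond the scatter) from compound 1 to compound 2 and a 1.2-fold higher number (0.07 log units; within the scatter) from compound 3 to compound 4, 2.8-fold (0.45 log units) apart, beyond the scatter of two such steps. This shows that the change does not carry a fixed size between these two cores, but two pairs cannot show why the steps differ or how the change would behave on any other core.

The compounds shown leave open whether a longer chain such as propyl, or a cyclopropyl group, in the same place would follow either step. Also open, from the compounds shown here alone, is which part of the difference between the two cores goes with the different steps.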